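Dichlorophenyl for vinylphenyl on the shared amide core

The source may report more compounds than this note shows. Statements on the series, on what has been measured and on what is new or still open speak of the compounds shown alone.

Measured compounds:
compound 1 `C=Cc1cccc(C(=O)NCN2CCC(c3cccc[n+]3[O-])CC2)c1`: 63%
compound 2 `Oc1ccc(N2CCN(Cc3nc4ccccc4[nH]3)CC2)nc1`: 70%
compound 3 `O=C(CN1CCC(c2cccc[n+]2[O-])CC1)Nc1cccc(C(F)(F)F)c1`: 75%

In a functional assay on HEK293 cells for agonist activity at D(4) dopamine receptor (Homo sapiens), read by FLIPR (on this read-out lower numbers stand for smaller maximal responses and higher numbers for larger maximal responses), compound 1 gives 63%, the lowest of the three numbers shown. Compound 2 gives 70%, which lies within the scatter of compound 1, so the two are not distinguishable here. Compound 3 gives 75%, a number beyond the scatter above compound 1.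

Compound 4 `O=C(NCN1CCC(c2cccc[n+]2[O-])CC1)c1cc(Cl)cc(Cl)c1` has not been measured. It differs from compound 1 by 3,5-dichlorophenyl in place of 3-vinylphenyl on a carbonyl carbon. For the measured compounds named here, no measured pair shows a change of this kind, so there is no step to lean on. The step of a number 4 percentage points higher from compound 1 to compound 4 (within the scatter) is expected to stay within the scatter, with no clear direction. Compound 4 is expected to give 67%, in the range 50% to 85%.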

Compound 4, largest response reached (reported as efficacy), in percent of the reference or control that the assay uses: 64%
Compound 4: middle estimate off by 3 percentage points, on the high side; measured number inside the range.
By their numbers in this assay, from the lowest: compounds 1, 4, 2 and 3 (each within the scatter of the next, the first and the last beyond it).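

In this assay, the only one-place pair shown gives a step that is a number 1 percentage points higher from compound 1 to compound 4 (within the scatter), for 3,5-dichlorophenyl in place of 3-vinylphenyl on a carbonyl carbon. At this place, then, one aromatic carbon ring with two chlorines and one with a vinyl group cannot be told apart on maximal response, so the vinyl double bond is not needed to hold the response at this level. Nothing on hand explains this result.

Still open, from the compounds shown here alone, is whether a carboxylic acid or an amine on the phenyl ring at this place would move the response beyond the scatter. A single chlorine on that ring is also untested in the compounds shown, so the separate contribution of each chlorine remains unknown.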